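The source may hold more compounds than are shown below. What is called first, only, known or untested is meant among the compounds shown, and "the series" means these compounds.

Measured compounds:
Compound 1 `Cn1cnc2c1c(=O)n(CC(=O)N1CCN(c3ccccc3)CC1)c(=O)n2C` gives 4.6% in a functional assay on MGC-803 cells (Homo sapiens) for inhibition, read by MTT assay, with a stated time of 48 h, tested at 20 uM; on this read-out lower numbers stand for less inhibition and higher numbers for more inhibition at the one concentration tested (going by the name of the read-out).
Compound 2 `Cc1ccc(S(=O)(=O)N2CCN(C(=O)Cn3c(=O)c4c(ncn4C)n(C)c3=O)CC2)cc1` gives 20.1% in this assay.

Compound 2 stands highest of the two numbers shown; its nearest neighbour is compound 1, and the step of a number 15.5 percentage points higher from compound 1 to compound 2 (beyond the scatter) is beyond the scatter, though modest in size. Compound 3 `Cn1cnc2c1c(=O)n(CC(=O)N1CCN(C(=O)/C=C/c3ccccc3)CC1)c(=O)n2C` is not yet measured. It differs from compound 2 in one place: (2-phenylethenyl)carbonyl in place of (4-methylphenyl)sulfonyl on an amine nitrogen in a ring. Among the measured compounds shown here, the only measured step that bears on this position is a number 15.5 percentage points higher from compound 1 to compound 2 (beyond the scatter), which shows that exchanging the group on that ring nitrogen can move the inhibition modestly, in either direction as far as these data reveal. For the measured compounds named here, no measured pair shows a (2-phenylethenyl)carbonyl group, so the direction for compound 3 is uncertain and a change within the scatter is as plausible as a modest one. Compound 3 is therefore expected to give about 15%, within 2% to 38%. The estimated step of a number 5.1 percentage points lower from compound 2 to compound 3 (within the scatter) is expected to be small.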

Compound 3, a percentage reported as inhibition, at one concentration (the size of the read-out at that concentration, not a potency): 9.5%
Compound 3: the middle estimate sits 5.5 percentage points above what was measured; measured number inside the range.
By their numbers in this assay, from the lowest: compounds 1 and 3 (each within the scatter of the next); then compound 2.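

On the amine nitrogen in the ring, (2-phenylethenyl)carbonyl in place of (4-methylphenyl)sulfonyl gives a number 10.6 percentage points lower from compound 2 to compound 3 (beyond the scatter) in this assay, so the higher number of compound 2 does not carry over to this group, even though the two groups have the same count of heavy atoms and each holds one six-membered aromatic ring. Against phenyl at the same nitrogen, the change gives a number 4.9 percentage points higher from compound 1 to compound 3 (within the scatter), so of the three groups only (4-methylphenyl)sulfonyl stands apart. Nothing measured here accounts for this difference. The compounds shown leave open whether the sulfonyl link or the methyl on its phenyl ring goes with the higher number. As far as these compounds go, a benzoyl or a methanesulfonyl group on that nitrogen would help to separate these parts, and its reading remains open.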